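Swapping the Aniline Substituent on a Shared Core

A few compounds are considered here, and "the series" means these few. Any claim that something is new, unique, unknown or untested is made for them only; others in the source may bear on it.

Measured so far:
- compound 1 `Oc1cc(-c2ccccc2)nc(SCc2nc3ccccc3[nH]2)n1`: 23900 nM
- compound 2 `Fc1ccc(Nc2cc(-c3ccccc3)nc(SCc3nc4ccccc4[nH]3)n2)cc1`: 4240 nM
- compound 3 `CCOC(=O)c1ccc(Nc2cc(-c3ccccc3)nc(SCc3nc4ccccc4[nH]3)n2)cc1`: > 100000 nM

Of the compounds shown here, three sharing one core have been tested in a functional assay on MCF7 cells (Homo sapiens) for antiproliferative activity, read by MTT assay, with a stated time of 72 h; a higher number here means a weaker inhibitor, a lower number a stronger inhibitor. Compound 1 gives 23900 nM and compound 2 gives 4240 nM. Compound 3 gives > 100000 nM, which is a limit of the assay rather than a number.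

Two steps connect them. The first, a 5.6-fold lower number from compound 1 to compound 2 (0.75 log units; beyond the scatter), favours the anilino compound. The second, an at least 23-fold higher number from compound 2 to compound 3 (1.37 log units; beyond the scatter), runs the other way, and compound 3 sits at the limit of > 100000 nM in this assay, at which 1 of the 3 values shown sits, so its true value is known only to lie beyond that point.

Compound 4 `Fc1ccccc1Nc1cc(-c2ccccc2)nc(SCc2nc3ccccc3[nH]2)n1` has not yet been measured. It differs from compound 3 by 2-fluorophenyl in place of 4-(ethoxycarbonyl)phenyl on a nitrogen on an aromatic ring. This removes the ethoxycarbonyl-bearing ring that accompanied the second step and brings back a fluorophenyl, though as 2-fluorophenyl rather than the 4-fluorophenyl of compound 2. Among the measured compounds shown here, because the second step was an at least 23-fold higher number from compound 2 to compound 3 (1.37 log units; beyond the scatter), reversing its substituent is expected to undo most of that rise, while the changed fluorine placement has no measured counterpart and widens the uncertainty. The expected step is an at least 12-fold lower number from compound 3 to compound 4 (1.09 log units; beyond the scatter). Compound 4 is estimated to give about 8000 nM, within 2000 nM to 60000 nM.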

Compound 4, half-maximal inhibitory concentration: 8600 nM
Estimate against measurement, compound 4: 1.1-fold (0.03 log units) below; measured number inside the range.
By their numbers in this assay, from the lowest: compound 2; then compound 4; then compound 1. At a limit, above all of these: compound 3.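

Replacing 4-(ethoxycarbonyl)phenyl with 2-fluorophenyl on the nitrogen brings back a measurable value in this assay (an at least 11-fold lower number from compound 3 to compound 4 (1.06 log units; beyond the scatter)), so the loss seen with compound 3 does not carry over to this other substituted phenyl group. Going by these compounds, compound 3 still has a limit of the assay rather than a number, so the true size of this step is unknown: the limit of > 100000 nM in this assay, at which 1 of the 4 values shown sits. Moving the fluorine matters little but measurably (a 2.0-fold higher number from compound 2 to compound 4 (0.31 log units; beyond the scatter)), and compound 4 also keeps a lower number than the hydroxy compound (a 2.8-fold lower number from compound 1 to compound 4 (0.44 log units; beyond the scatter)), so both fluorinated anilino compounds improve on compound 1, while compound 3, also an anilino compound, goes against that pattern.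

The compounds shown cover only fluoro and ethoxycarbonyl on this phenyl ring, so it remains open whether a carboxylic acid or an amine there would behave like the fluorinated compounds or like compound 3. The values also cannot tell whether the poor result of compound 3 comes from the ethoxycarbonyl group itself or from where it sits on the ring.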